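A few compounds are considered here, and "the series" means these few. Any claim that something is new, unique, unknown or untested is made for them only; others in the source may bear on it.

Measured in an ADME assay on CCRF-CEM cells (Homo sapiens) for cytotoxicity, with a stated time of 5 days; on this read-out higher numbers stand for weaker inhibition and lower numbers for stronger inhibition:
compound 1 `COc1nc(F)nc2c1ncn2[C@H]1C[C@H](N=[N+]=[N-])[C@@H](CO)O1`: > 100000 nM
compound 2 `COc1nc(OC)c2ncn([C@H]3C[C@H](N=[N+]=[N-])[C@@H](CO)O3)c2n1`: > 100000 nM
compound 3 `COc1nc(Cl)nc2c1ncn2[C@H]1C[C@H](N=[N+]=[N-])[C@@H](CO)O1`: > 100000 nM

Each of these values is a limit and not a number: the limit of > 100000 nM in this assay, at which 3 of the 3 values shown sit. Compound 1 therefore has no number of its own to start from.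

Compound 4 `[N-]=[N+]=N[C@H]1C[C@H](n2cnc3c(N)nc(F)nc32)O[C@@H]1CO` carries amino in place of methoxy on an aromatic carbon. The nearest measured steps are a step that the two limits leave unreadable from compound 1 to compound 2, a step that the two limits leave unreadable from compound 1 to compound 3 and a step that the two limits leave unreadable from compound 2 to compound 3. Their sizes cannot be read, and none of them introduces amino, so they give only weak guidance. In this assay a modest shift towards stronger inhibition is expected, though another limit remains quite possible. The expected step, an estimate only, is an at least 2.0-fold lower number from compound 1 to compound 4 (0.30 log units; that floor lies within the scatter). For compound 4 the estimated value is 50000 nM, with an expected range of 5000 nM to 100000 nM.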

Compound 4, half-maximal inhibitory concentration: 30100 nM
For compound 4 the middle estimate is 1.7-fold (0.22 log units) above the measured one; the measured number falls inside the stated range.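

In this assay, amino in place of methoxy on an aromatic carbon, next to the ring nitrogen and ortho to a fused ring, gives an at least 3.3-fold lower number from compound 1 to compound 4 (0.52 log units; beyond the scatter). This position therefore responds to the change, and compound 4 alone gives a number. The steps among the other compounds cannot be read, and compound 1, compound 2 and compound 3 remain limits: the limit of > 100000 nM in this assay, at which 3 of the 4 values shown sit.

Going by these compounds, the full size of the step stays open, as compound 1 has only a limit. Also open, on these data alone, is how methylamino, dimethylamino or hydroxyl in this place would compare with amino on the core of compound 4.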